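Pyridinyl replacing cyanophenyl on a shared tricyclic core

A few compounds are considered here, and "the series" means these few. Any claim that something is new, unique, unknown or untested is made for them only; others in the source may bear on it.

Compound 1 `N#Cc1ccc(-c2cnc3[nH]cc(-c4nnc(-c5ccc(F)cc5)o4)c(=O)c3c2)cc1`: 10.2%
Compound 2 `N#Cc1ccc(-c2cnc3[nH]cc(-c4nnc(-c5ccc(Cl)cc5)o4)c(=O)c3c2)cc1`: 13.7%
Compound 3 `CS(=O)(=O)c1ccc(-c2cnc3[nH]cc(-c4nnc(-c5cccnc5)o4)c(=O)c3c2)cc1`: 4.32%

In a functional assay on HCT-116 cells (Homo sapiens) for inhibition, read by MTT assay, with a stated time of 24 h, tested at 2.5 uM (a lower number here means less inhibition of growth, a higher number more inhibition of growth at the concentration tested), compound 1 gives 10.2%, the second highest of the three numbers; compound 2 and compound 3 both lie within the scatter of it. Among the measured compounds shown here, the only measured step, a number 3.5 percentage points higher from compound 1 to compound 2 (within the scatter), concerns a different position than the change studied here. Compound 4 `O=c1c(-c2nnc(-c3ccc(F)cc3)o2)c[nH]c2ncc(-c3ccncc3)cc12` differs from compound 1 by pyridin-4-yl in place of 4-cyanophenyl on an aromatic carbon. For the measured compounds named here, no measured pair shows this change, so the expectation rests on the narrow spread of all three numbers, and the step of a number 1.2 percentage points lower from compound 1 to compound 4 (within the scatter) is expected to stay within the scatter. Compound 4 is therefore estimated at 9%, with a range from 0% to 22%.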

Compound 4, percent growth inhibition at one concentration: 7.54%
For compound 4 the middle estimate is 1.5 percentage points above the measured one, within the range that was stated.
By their numbers in this assay, from the lowest: compounds 3, 4, 1 and 2 (each within the scatter of the next).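

Among the compounds shown here, measured in this assay, pyridin-4-yl in place of 4-cyanophenyl gives a number 2.7 percentage points lower from compound 1 to compound 4 (within the scatter), the first reading of a change at this aromatic carbon. The nitrile and the all-carbon ring can therefore both go from this position with no readable change in growth inhibition at the concentration tested. Nothing measured here offers an explanation for this result. On these data alone, whether a morpholine or a simple amine on this carbon would give a step beyond the scatter stays open. So does whether pyridin-4-yl gives the same result alongside the chloro group of compound 2.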